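A few compounds are considered here, and "the series" means these few. Any claim that something is new, unique, unknown or untested is made for them only; others in the source may bear on it.

Three compounds have been measured in a functional assay on cells (Tumor Cell line, Homo sapiens) for cytotoxicity; a lower number here means a stronger inhibitor, a higher number a weaker inhibitor:

compound 1, `CN(C)Cc1cc(C(=O)/C=C/c2cccc(Cl)c2)cc(CN(C)C)c1O`: 4680 nM
compound 2, `CN(C)Cc1cc(C(=O)/C=C/c2ccc(Cl)c(Cl)c2)cc(CN(C)C)c1O`: 2350 nM
compound 3, `CN(C)Cc1cc(C(=O)/C=C/c2ccc(Br)cc2)cc(CN(C)C)c1O`: 6310 nM

Compound 1 stands second highest of these three numbers. Its nearest neighbour is compound 3, with a 1.3-fold higher number from compound 1 to compound 3 (0.13 log units; within the scatter); its furthest is compound 2, with a 2.0-fold lower number from compound 1 to compound 2 (0.30 log units; within the scatter). Within the data shown here, the only step that goes beyond the scatter is the one between the other two, a 2.7-fold higher number from compound 2 to compound 3 (0.43 log units; beyond the scatter), and even that is modest. The whole set therefore sits in a narrow band.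

Compound 4, `CN(C)Cc1cc(C(=O)/C=C/c2ccc([N+](=O)[O-])cc2)cc(CN(C)C)c1O`, has not yet been measured. It differs from compound 1 in one place: 4-nitrophenyl in place of 3-chlorophenyl on a double-bonded chain carbon bound to a double-bonded chain carbon. Among the measured compounds shown here, no measured step exchanges a halogen-bearing ring for a nitro-bearing one, so nothing speaks directly to this change. The two steps that alter the same ring, from compound 1 to compound 2 and to compound 3, both stayed within the scatter. On that basis no step beyond the scatter is expected in this assay, in either direction. Compound 4 is estimated to give 4500 nM, within a range from 2000 nM to 10000 nM. This estimate corresponds to an expected step of a 1.0-fold lower number from compound 1 to compound 4 (0.02 log units; within the scatter).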

Compound 4, half-maximal inhibitory concentration: 8910 nM
Compound 4: middle estimate off by 2.0-fold (0.30 log units), on the low side; low and high end bracket the measured number.
By their numbers in this assay, from the lowest: compounds 2, 1, 3 and 4 (each within the scatter of the next, the first and the last beyond it).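

In this assay, among these compounds, a 4-nitrophenyl group on the double-bonded chain carbon, the first group here without a halogen, stays within the scatter of the 3-chlorophenyl group, as a 1.9-fold higher number from compound 1 to compound 4 (0.28 log units; within the scatter) shows. Exchanging bromo for nitro on the same ring also makes no clear difference, with a 1.4-fold higher number from compound 3 to compound 4 (0.15 log units; within the scatter) as the step. Among the compounds shown here, the one step beyond the scatter starts from the 3,4-dichlorophenyl group, a 3.8-fold higher number from compound 2 to compound 4 (0.58 log units; beyond the scatter), and it is modest, so this position has so far tolerated these different ring groups with little change in the number.

No available evidence explains these differences. As far as these compounds go, it remains open whether an amine or a carboxylic acid on this ring, or a longer chain in its place, would move the number further.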